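Propyl trimmed from a dipropylamine on a shared core

The compounds below may be only part of what the source reports. "The series", "measured", "known", "first", "only" and "open" are said of these compounds alone.

In a functional assay on HEK293 cells for agonist activity at 5-hydroxytryptamine receptor 7 (Homo sapiens), read by a luciferase reporter and beta-arrestin recruitment, with a stated time of 22 h (on this read-out lower numbers stand for an effect already at smaller amounts and higher numbers for an effect only at larger amounts of compound), compound 1 `CCCN(CCC)Cc1ccc(Cl)c(-c2ccccc2OC)c1` stands without a number and is recorded as "not active" (no number reported). Compound 2 `CNCc1ccc(Cl)c(-c2ccccc2OC)c1` gives 148 nM; 150 nM (2 entries) in this assay, a result repeated in the several entries of compound 2 in this assay, 148 nM; 150 nM (2 entries). Compound 3 `CCCCNCc1ccc(Cl)c(-c2ccccc2OC)c1` is recorded as "not active" (no number reported) in this assay. Compound 4 `CCCNCc1ccc(Cl)c(-c2ccccc2OC)c1` has not yet been measured. It differs from compound 1 by hydrogen in place of propyl on an amine nitrogen. Going by the values given here, no measured pair shows this change by itself, so the size of the step in this assay cannot be read from the numbers; the secondary amines run from compound 2 with a number to compound 3 without one. Compound 4 is expected to fall around 2500 nM, between 500 nM and 12000 nM, with a fair chance of no number at all.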

Compound 4, half-maximal effective concentration: "not active" (no number reported)
No number was reported for compound 4, and the estimate cannot be compared.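

Compound 1 and compound 4 both stand without a number in this assay, so no step between them can be read, and nothing shown accounts for this result. The compounds shown leave open how large the change from dipropylamino to propylamino is on the shared core.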